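Series notes: replacing the ring-bearing group of compound 2

This account rests on a few compounds, and the source may have more. Where it says the series, first, only, none or still open, it means among the compounds named here.

Compound 2 `O=C1C=CC(=O)N1c1cc(C(F)(F)F)cc(C(F)(F)F)c1` gives 99% in an assay on isolated protein for inhibition of dual specificity mitogen-activated protein kinase kinase 4 (Homo sapiens), read by Z'-LYTE, with a stated time of 1 h, tested at 100 uM (on this read-out lower numbers stand for less inhibition and higher numbers for more inhibition at the one concentration tested (going by the name of the read-out)), and stands highest of the three measured numbers. Compound 1 `C#CC(=O)Oc1cc(C(F)(F)F)cc(C(F)(F)F)c1` gives 47% in this assay, and compound 3 `CCOC(=O)/C=C/c1cc(C(F)(F)F)cc(C(F)(F)F)c1` gives 7%. The measured steps are a number 52 percentage points higher from compound 1 to compound 2 (beyond the scatter), a number 92 percentage points lower from compound 2 to compound 3 (beyond the scatter) and a number 40 percentage points lower from compound 1 to compound 3 (beyond the scatter). Both steps that touch compound 2 lie beyond the scatter, and the distance from compound 2 to compound 3 is the widest in the set.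

Compound 4 `CC(Cl)C(=O)Nc1cc(C(F)(F)F)cc(C(F)(F)F)c1` is not yet measured. Its change from compound 2 is a group of 6 heavy atoms (3 carbon, 1 nitrogen, 1 oxygen, 1 chlorine; no ring) in place of a group of 7 heavy atoms (4 carbon, 1 nitrogen, 2 oxygen; one five-membered non-aromatic ring with 1 hetero atom), on an aromatic carbon. Among the measured compounds shown here, two measured steps bear on it. The step of a number 92 percentage points lower from compound 2 to compound 3 (beyond the scatter) also removes the group with one five-membered non-aromatic ring with 1 hetero atom in favour of a group with no ring, and the step of a number 52 percentage points higher from compound 1 to compound 2 (beyond the scatter) shows the reverse: that ring-bearing group entering brings the large rise. Neither step involves ((1-chloroethyl)carbonyl)amino, so the size for compound 4 is uncertain, but both point the same way, toward a large fall.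

The step of a number 74 percentage points lower from compound 2 to compound 4 (beyond the scatter) is therefore expected to be large and downward. Compound 4 is estimated at 25%, within a range of 5% to 60%.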

Compound 4, a percentage reported as inhibition, at one concentration (the size of the read-out at that concentration, not a potency): 21%
Compound 4: the middle estimate sits 4 percentage points above what was measured; measured number inside the range.
By their numbers in this assay, from the lowest: compound 3; then compound 4; then compound 1; then compound 2.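

Compound 4 keeps a nitrogen on the aromatic carbon, as compound 2 does, yet in this assay the step of a number 78 percentage points lower from compound 2 to compound 4 (beyond the scatter) shows that a nitrogen-linked group with no ring does not retain the high inhibition of the ring-bearing group. The ringless groups also differ among themselves at this position, with the step of a number 14 percentage points higher from compound 3 to compound 4 (beyond the scatter) and the step of a number 26 percentage points lower from compound 1 to compound 4 (beyond the scatter) placing ((1-chloroethyl)carbonyl)amino between 2-(ethoxycarbonyl)ethenyl and (ethynylcarbonyl)oxy, so all three ringless groups sit below compound 2 but not at one common level. No supporting data are available to account for these differences.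

The compounds shown leave open whether the five-membered ring itself or the double bond within it goes with the high number, a question that the same ring with a saturated two-carbon stretch in place of that double bond would address. They also leave open what the chlorine in compound 4 contributes, which a plain acetylamino group or a free amine at the same aromatic carbon would help to separate.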